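Hexyloxy in place of cyclohexylamino: expected tolerance

The compounds below may be only part of what the source reports. "The series", "measured", "known", "first", "only" and "open" are said of these compounds alone.

Compound 1 `CCCNc1nc(N)nc2c1ncn2/C=C1/CC1(CO)CO` gives > 300000 nM (a limit)
Compound 2 `Nc1nc(NC2CCCCC2)c2ncn(/C=C3/CC3(CO)CO)c2n1` gives > 300000 nM (a limit)
Compound 3 `CCCCCCOc1nc(N)nc2c1ncn2/C=C1/CC1(CO)CO` is not yet measured

In an ADME assay on HFF cells (Homo sapiens) for cytotoxicity, with a stated time of 8 days (a lower number here means that less compound is tolerated, a higher number that more compound is tolerated), compound 2 stands at > 300000 nM as a limit, not a number. The change to compound 3 is hexyloxy in place of cyclohexylamino on an aromatic carbon and reads hexyloxy in place of cyclohexylamino on an aromatic carbon. Going by the values given here, the one measured step (a step that the two limits leave unreadable from compound 1 to compound 2) has no readable size, and both measured compounds sit at the same limit (the limit of > 300000 nM in this assay, at which 2 of the 2 values shown sit), so no size carries over. Compound 3 is expected to stay near that limit or fall modestly. The estimated step (an at least 1.5-fold lower number from compound 2 to compound 3 (0.17 log units; that floor lies within the scatter)) is therefore small and downward. For compound 3 the expected value is 200000 nM with an estimated range of 50000 nM to 300000 nM in this estimate.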

Compound 3, half-maximal cytotoxic concentration: > 200000 nM
Compound 3: a limit, no number (the forecaster's own chance of this, stated with the estimate: 55%); the middle value sits exactly at the limit.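

In this assay, going by these compounds alone, compound 1, compound 2 and compound 3 all give limits, so no step among them can be read. The compounds shown leave open the concentration at which any of the three becomes cytotoxic, and so whether hexyloxy and cyclohexylamino differ at all.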